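The source may report more compounds than this note shows. Statements on the series, on what has been measured and on what is new or still open speak of the compounds shown alone.

Measured in a physicochemical assay for solubility, in phosphate buffer, at pH 7.4; on this read-out higher numbers stand for higher solubility and lower numbers for lower solubility:
- Compound 1 `CC(=O)N[C@@H]1CCC[C@H](C(=O)Nc2cc(-c3nnn4ccccc34)c(Cl)cn2)C1`: 530000 nM
- Compound 2 `CC(=O)N[C@@H]1CCC[C@H](C(=O)Nc2cc(-c3cnc4n3CCC4)c(Cl)cn2)C1`: 490000 nM
- Compound 3 `CC(=O)N[C@@H]1CCC[C@H](C(=O)Nc2cc(-c3cnn4c3CC(C)C4)c(Cl)cn2)C1`: 79000 nM; 159000 nM (2 entries)

Among the measured compounds shown here, the one measured step, a 1.1-fold lower number from compound 1 to compound 2 (0.03 log units; within the scatter), stays within the scatter, so those two compounds cannot be ranked. Compound 3 is spread over (the several entries of compound 3 in this assay, 79000 nM; 159000 nM (2 entries)), and both entries are smaller numbers than compound 2 at 490000 nM.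

Compound 4 `CC(=O)N[C@@H]1CCC[C@H](C(=O)Nc2cc(-c3cnc4n3CC(C)(C)C4)c(Cl)cn2)C1` differs from compound 2 in one group: a group of 10 heavy atoms (8 carbon, 2 nitrogen; one five-membered non-aromatic ring with 1 hetero atom, one five-membered aromatic ring with 2 hetero atoms) in place of a group of 8 heavy atoms (6 carbon, 2 nitrogen; one five-membered non-aromatic ring with 1 hetero atom, one five-membered aromatic ring with 2 hetero atoms), on an aromatic carbon. The group sits ortho to a chloro group, opposite the ring nitrogen.

For the measured compounds named here, no measured step makes this exact exchange. The exchange already measured at this place moved nothing beyond the scatter, while compound 3 at 79000 nM; 159000 nM (2 entries) marks the lower numbers seen so far. A modest move towards lower numbers is therefore expected, and the estimated change is a 2.0-fold lower number from compound 2 to compound 4 (0.29 log units; within the scatter). For compound 4 the expected value in this assay is 250000 nM, with an estimated range of 80000 nM to 600000 nM.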

Compound 4, solubility: 280000 nM
Beside the measured number, compound 4's estimate is 1.1-fold (0.05 log units) below it; measured number inside the range.
By their numbers in this assay, from the lowest: compounds 4, 2 and 1 (each within the scatter of the next).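

With the group of 10 heavy atoms on the aromatic carbon opposite the ring nitrogen, this assay gives a 1.8-fold lower number from compound 2 to compound 4 (0.24 log units; within the scatter) and a 1.9-fold lower number from compound 1 to compound 4 (0.28 log units; within the scatter). Even this larger group therefore gives no step beyond the scatter at this position, so compound 4, compound 2 and compound 1 cannot be ranked. The repeat entries of a single compound span a similar width: the several entries of compound 3 in this assay, 79000 nM; 159000 nM (2 entries).

Going by these compounds, it remains open whether an amine or a carboxylic acid on the group at this position would give a step beyond the scatter in this assay.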